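The compounds below may be only part of what the source reports. "The series", "measured", "known", "first", "only" and "open" are said of these compounds alone.

Measured in a functional assay on the whole organism with Mus musculus as the target, in the rotarod test; on this read-out higher numbers stand for an effect only at larger amounts of compound and lower numbers for an effect already at smaller amounts:
Compound 1 `CC(=O)NCC(=O)Nc1ccc(Cl)cc1C(=O)c1ccccc1` returns only a limit, > 100 mg/kg.
Compound 2 `CCCCCC(=O)NCC(=O)N(C)c1ccc(Cl)cc1C(=O)c1ccccc1Cl` gives 90 mg/kg.
Compound 3 `CCCCCCC(=O)NCC(=O)N(C)c1ccc(Cl)cc1C(=O)c1ccccc1Cl` gives 70 mg/kg.

Going by the values given here, compound 2 and compound 3 are the only two numbers in hand, and they sit within the scatter of each other: a 1.3-fold lower number from compound 2 to compound 3 (0.11 log units; within the scatter). Compound 4 `CCN(CC)CC(=O)NCC(=O)N(C)c1ccc(Cl)cc1C(=O)c1ccccc1Cl` is to be measured in this assay. Against compound 2 it carries diethylamino in place of butyl on a saturated chain carbon bound to a carbonyl carbon. Among the compounds with values here, the single measured step, methyl in place of hydrogen on a saturated chain carbon five bonds along the chain from a carbonyl carbon, was a 1.3-fold lower number from compound 2 to compound 3 (0.11 log units; within the scatter); no measured step exchanges butyl for diethylamino, and none alters the chain on the carbon bound to the carbonyl. With nothing beyond the scatter among the measured steps, no step beyond the scatter is expected in this assay for compound 4. Compound 4 is estimated at 80 mg/kg, with a range from 40 mg/kg to 200 mg/kg. The expected step is therefore a 1.1-fold lower number from compound 2 to compound 4 (0.05 log units; within the scatter).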

Compound 4, dose for half-maximal effect: 34 mg/kg
For compound 4 the middle estimate is 2.4-fold (0.37 log units) above the measured one, and the stated range ends above it.
By their numbers in this assay, from the lowest: compound 4; then compounds 3 and 2 (each within the scatter of the next). At a limit, above all of these: compound 1.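

In this assay, this position responds beyond the scatter: diethylamino in place of butyl on a saturated chain carbon bound to a carbonyl carbon gives a 2.6-fold lower number from compound 2 to compound 4 (0.42 log units; beyond the scatter). Diethylamino in place of pentyl at the same place gives a 2.1-fold lower number from compound 3 to compound 4 (0.31 log units; beyond the scatter), whereas the step between the two alkyl chains stayed at a 1.3-fold lower number from compound 2 to compound 3 (0.11 log units; within the scatter). Nothing measured here accounts for these steps. Open, from the compounds shown here alone, is whether the lower number belongs to diethylamino alone or extends to other amines on this carbon, such as dimethylamino, piperidine or morpholine.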